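Series notes: methyl added to the benzyl ring

The source may report more compounds than this note shows. Statements on the series, on what has been measured and on what is new or still open speak of the compounds shown alone.

Compound 1 `COc1cc(/C=C/c2nc(Nc3ccc(C(F)(F)F)cc3)c3sccc3n2)cc(OC)c1OC` carries 4-(trifluoromethyl)phenyl on the ring nitrogen and gives 436000 nM in a functional assay on L02 cells (Homo sapiens) for inhibition, read by Griess assay, with stated times of 1 h and 24 h; on this read-out higher numbers stand for weaker inhibition and lower numbers for stronger inhibition. Compound 2 `COc1cc(/C=C/c2nc(NCc3ccccc3)c3sccc3n2)cc(OC)c1OC` has benzyl in its place. In this assay compound 2 reaches only the limit of the assay, > 1000000 nM, and no number. The step of an at least 2.2-fold higher number from compound 1 to compound 2 (0.36 log units; beyond the scatter) thus rests on one side on a limit, (the limit of > 1000000 nM in this assay, at which 1 of the 2 values shown sits); compound 2 stands at the weak end of the two values shown, its number known only as beyond that limit.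

Compound 3 `COc1cc(/C=C/c2nc(NCc3ccc(C)cc3)c3sccc3n2)cc(OC)c1OC` differs from compound 2 by methyl in place of hydrogen on an aromatic carbon, para to a large group, so that benzylamino becomes (4-methylbenzyl)amino. Among the compounds with values here, no measured step covers a change of this kind; the only measured step, an at least 2.2-fold higher number from compound 1 to compound 2 (0.36 log units; beyond the scatter), concerns exchange of the whole group on the nitrogen and bears on the present step only in that the benzyl series starts at the limit. A methyl is expected to move the number little in this assay, so compound 3 is expected to stay near or beyond the limit. Compound 3 is estimated at 1500000 nM, range 400000 nM to 5000000 nM, meaning an expected step that the limit leaves unreadable from compound 2 to compound 3.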

Compound 3, half-maximal inhibitory concentration: > 1000000 nM
Compound 3: a limit, no number; the forecaster's own chance of this, stated with the estimate: 75%; the middle value is on the limit's open side.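

In this assay compound 3 gives > 1000000 nM, a limit of the assay and not a number. Methyl in place of hydrogen on the benzyl ring, para to a large group, therefore does not bring this part of the series into the readable range, and the step from the unsubstituted benzyl cannot be read, since both of its values are limits: the limit of > 1000000 nM in this assay, at which 2 of the 3 values shown sit.

Exchange of 4-(trifluoromethyl)phenyl for 4-methylbenzyl on the nitrogen gives an at least 2.2-fold higher number from compound 1 to compound 3 (0.36 log units; beyond the scatter), so the only readable number among the compounds shown still belongs to the 4-(trifluoromethyl)phenyl group.

On these data alone, whether the methyl changes anything beyond the limit remains open, as does whether any group on the benzyl ring can return a readable number. A 4-(trifluoromethyl)benzyl group or a plain phenyl on the nitrogen would separate the contribution of the trifluoromethyl from that of the methylene of the benzyl group, which the compounds shown do not do.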